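The source may report more compounds than this note shows. Statements on the series, on what has been measured and on what is new or still open speak of the compounds shown alone.

Measured in a functional assay for inhibition, with Homo sapiens as the target; a higher number here means a weaker inhibitor, a lower number a stronger inhibitor:

- compound 1 `Cc1cc2c(cc1C(=O)N=C(N)N)S(=O)(=O)CCCC2`: 274 nM
- compound 2 `Cc1cc2c(cc1C(=O)N=C(N)N)S(=O)(=O)CC2C(C)C`: 77 nM
- compound 3 `C=C1c2cc(C)c(C(=O)N=C(N)N)cc2S(=O)(=O)C1(C)C`: 114 nM

Compound 2, at 77 nM, cannot be told apart from compound 3, at 114 nM, since the two values lie within the usual scatter of repeated measurements. Compound 1, at 274 nM, has a higher number than compound 2, and that gap lies beyond the scatter, so compound 2 is the stronger inhibitor of that pair.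

The next compound to be tested is compound 4 `CCC1CS(=O)(=O)c2cc(C(=O)N=C(N)N)c(C)cc21`. It is compound 2 with its isopropyl group cut back to ethyl: hydrogen in place of methyl on a saturated chain carbon bound to a saturated chain carbon and a saturated ring carbon. In other words, hydrogen takes the place of methyl on a saturated chain carbon bound to a saturated chain carbon and a saturated ring carbon.

Among the measured compounds shown here, no two measured compounds differ in only one place, so the data give no direct measure of a change like this one. The change itself is small, and the three measured compounds differ from one another by only a modest margin in this assay. A shift beyond the scatter is therefore not expected, and no firm direction can be claimed. The expected outcome is a 1.3-fold higher number from compound 2 to compound 4 (0.11 log units; within the scatter), an estimated step that stays within the scatter. For compound 4 the estimated value is 100 nM, with an expected range of 45 nM to 230 nM.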

Compound 4, half-maximal inhibitory concentration: 78 nM
Compound 4: middle estimate off by 1.3-fold (0.11 log units), on the high side, within the range that was stated.
By their numbers in this assay, from the lowest: compounds 2, 4 and 3 (each within the scatter of the next); then compound 1.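

Among the compounds shown here, this pair gives the first direct reading of a single change: in this assay, cutting isopropyl back to ethyl gives a 1.0-fold higher number from compound 2 to compound 4 (0.01 log units; within the scatter) and so produces no detectable shift. At this place, then, the branched isopropyl and the unbranched ethyl cannot be told apart, and the methyl that leaves is a carbon the activity in this assay does not visibly depend on, at least for this pair of compounds. Nothing available here explains why the two groups read alike, and a single step with two compounds is no general rule for this position.

Still open, going by these compounds, is how far this tolerance reaches: whether the same place would accept a bare hydrogen or a single methyl in place of the ethyl, or a longer chain such as butyl or a bulkier group such as tert-butyl or phenyl. Equally open is what a chain ending in an amine, a hydroxyl or a carboxylic acid would do here, since every group shown at this place so far is made only of carbon and hydrogen.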